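The source may hold more compounds than are shown below. What is called first, only, known or untested is meant among the compounds shown, and "the series" means these compounds.

Measured in a functional assay on a cell-free system (plasma, Homo sapiens), with a stated time of 3 min; on this read-out lower numbers stand for stronger inhibition and higher numbers for weaker inhibition:
Compound 1 `O=C(NCc1cc(Cl)ccc1-n1cnnn1)[C@@H]1C[C@H]2C[C@H]2N1C(=O)[C@H](O)c1ccccc1`: 680 nM
Compound 2 `CC(C)(C)[C@@H](O)C(=O)N1[C@H](C(=O)NCc2cc(Cl)ccc2-n2cnnn2)C[C@@H]2C[C@@H]21`: 1500 nM

Of these two, compound 2 at 1500 nM has the higher number, and the gap to compound 1 at 680 nM lies beyond the scatter. Compound 3 `O=C(NCc1cc(Cl)ccc1-n1cnnn1)[C@@H]1C[C@@H]2C[C@@H]2N1C(=O)[C@H](O)c1ccccc1` is reached from compound 2 by phenyl in place of tert-butyl on a saturated chain carbon bound to a carbonyl carbon and an oxygen on a saturated carbon, with phenyl in place of tert-butyl on a saturated chain carbon bound to a carbonyl carbon and an oxygen on a saturated carbon. Among the compounds with values here, no measured step isolates this change, so the expectation rests on thin evidence. Within the data shown here, the one pointer is compound 1, which also carries hydroxy(phenyl)methyl and gives 680 nM. A move to a lower number, probably beyond the scatter, is expected in this assay, and the estimated size is a 3.8-fold lower number from compound 2 to compound 3 (0.57 log units; beyond the scatter). The expected value for compound 3 is 400 nM, with an estimated range of 80 nM to 1800 nM.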

Compound 3, half-maximal inhibitory concentration: 620 nM
For compound 3 the middle estimate is 1.6-fold (0.19 log units) below the measured one; the measured number falls inside the stated range.
By their numbers in this assay, from the lowest: compounds 3 and 1 (each within the scatter of the next); then compound 2.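

In this assay, phenyl in place of tert-butyl on a saturated chain carbon bound to a carbonyl carbon and an oxygen on a saturated carbon now has a measured step of its own: a 2.4-fold lower number from compound 2 to compound 3 (0.38 log units; beyond the scatter), a modest move. The second step, a 1.1-fold lower number from compound 1 to compound 3 (0.04 log units; within the scatter), stays within the scatter. This read-out therefore does not separate the two drawn forms carrying hydroxy(phenyl)methyl, and this single pair is the only view of the ring stereocentres: the fact that compounds 1 and 3 differ only in the configuration as drawn

Open, going by these compounds, is how an amine, a carboxylic acid or a longer chain would read in place of phenyl on this carbon. Also open, on these data alone, is whether the series holds its values with methoxy in place of the hydroxy group, or with the opposite configuration at the hydroxy-bearing carbon.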